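Swapping the benzimidazole on the triazole nitrogen of compound 3

The source may hold more compounds than are shown below. What is called first, only, known or untested is meant among the compounds shown, and "the series" means these compounds.

Compound 1 `CN(CCNCc1cn(CCCO)nn1)CCNc1ccnc2cc(Cl)ccc12` carries a 3-hydroxypropyl chain on one nitrogen of its triazole ring. In a functional assay on HCC827 cells (Homo sapiens) for antiproliferative activity, read by sulforhodamine B assay, with a stated time of 72 h (on this read-out higher numbers stand for weaker inhibition and lower numbers for stronger inhibition), compound 1 reaches only the limit of the test, > 200000 nM, which is a limit rather than a number (the limit of > 200000 nM in this assay, at which 1 of the 3 values shown sits). Compound 2 `CN(CCNCc1cn(Cc2nc3cc(Cl)ccc3[nH]2)nn1)CCNc1ccnc2cc(Cl)ccc12` gives 65000 nM in this assay, and compound 3 `CN(CCNCc1cn(-c2nc3ccccc3[nH]2)nn1)CCNc1ccnc2cc(Cl)ccc12` gives 32000 nM. Compound 3 therefore stands lowest of the two real numbers, with compound 2 nearest at a 2.0-fold lower number from compound 2 to compound 3 (0.31 log units; beyond the scatter). Both replacements of the hydroxyalkyl chain helped: an at least 3.0-fold lower number from compound 1 to compound 2 (0.48 log units; beyond the scatter) and an at least 6.2-fold lower number from compound 1 to compound 3 (0.79 log units; beyond the scatter).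

Compound 4 `CN(CCNCc1cn(CCCn2nn[nH]c2=O)nn1)CCNc1ccnc2cc(Cl)ccc12` changes this position once more: a group of 9 heavy atoms (4 carbon, 4 nitrogen, 1 oxygen; one five-membered aromatic ring with 4 hetero atoms) in place of a group of 9 heavy atoms (7 carbon, 2 nitrogen; one five-membered aromatic ring with 2 hetero atoms, one six-membered aromatic ring of carbon only), on an aromatic nitrogen. The step most closely bearing on it is an at least 6.2-fold lower number from compound 1 to compound 3 (0.79 log units; beyond the scatter), which shows that the benzimidazol-2-yl group is worth a good deal here, while a 2.0-fold lower number from compound 2 to compound 3 (0.31 log units; beyond the scatter) shows that putting a methylene between the ring nitrogen and the aromatic group costs something. Compound 4 returns to a three-carbon chain on that nitrogen, as in compound 1, so a clear move back toward weaker inhibition is expected, a 4.7-fold higher number from compound 3 to compound 4 (0.67 log units; beyond the scatter). The estimate for compound 4 in this assay is 150000 nM, within a range from 50000 nM to 600000 nM.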

Compound 4, half-maximal inhibitory concentration: > 200000 nM
Compound 4: no number, only a limit; the forecaster's own chance of this, stated with the estimate: 40%; middle value at least 1.3-fold (0.12 log units) away from the limit.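

Compound 4 gives no number in this assay, only a limit, and it shares that limit with compound 1: the limit of > 200000 nM in this assay, at which 2 of the 4 values shown sit.

So the new ring on the triazole nitrogen does not do the work of the benzimidazole groups: an at least 6.2-fold higher number from compound 3 to compound 4 (0.79 log units; beyond the scatter), and an at least 3.0-fold higher number from compound 2 to compound 4 (0.48 log units; beyond the scatter). Among these compounds, the earlier compounds showed only that these benzimidazole groups outperform a hydroxyalkyl chain, whereas compound 4 shows that the gain does not follow from having just any aromatic ring at this position, even one with the same heavy-atom count and hydrogen-bond donor count as 1H-benzimidazol-2-yl. The step from compound 1 to compound 4 cannot be read, since both values are limits, so nothing can be said about any order of these two compounds.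

The compounds shown leave open whether the loss in compound 4 comes from the new ring or from the chain that carries it, as they do not include 1H-benzimidazol-2-yl on a three-carbon chain. They also leave open whether a simple phenyl group on the triazole nitrogen would keep the activity of compound 3.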